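A few compounds are considered here, and "the series" means these few. Any claim that something is new, unique, unknown or untested is made for them only; others in the source may bear on it.

Compound 1 `C#CCNCc1cn(-c2cc(NC(=S)NCC)ncn2)cn1`: 5240 nM
Compound 2 `C#CCN(CCCC)Cc1cn(-c2cc(NC(=S)NCC)ncn2)cn1`: > 50000 nM

In an assay on isolated protein for inhibition of Amine oxidase [flavin-containing] B (Homo sapiens), read by fluorescence and Amplex Red, with a stated time of 15 min (a lower number here means a stronger inhibitor, a higher number a weaker inhibitor), compound 1 gives 5240 nM, the only number shown in the series. Compound 2 gives > 50000 nM, which is a limit of the assay and not a number. Compound 3 `C#CCN(Cc1cn(-c2cc(NC(=S)NCC)ncn2)cn1)C(C)=O` differs from compound 1 by acetyl in place of hydrogen on an amine nitrogen. Among the measured compounds shown here, one measured step bears on this change, at the same amine nitrogen: an at least 9.5-fold higher number from compound 1 to compound 2 (0.97 log units; beyond the scatter), with compound 2 sitting at the limit of > 50000 nM in this assay, at which 1 of the 2 values shown sits. Acetyl is not butyl, but on that step a weakening beyond the scatter is expected, a 5.7-fold higher number from compound 1 to compound 3 (0.76 log units; beyond the scatter). Compound 3 is therefore estimated at 30000 nM, between 8000 nM and 100000 nM.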

Compound 3, half-maximal inhibitory concentration: > 50000 nM
Compound 3 ended at the assay's limit; the forecaster's own chance of this, stated with the estimate: 40%; middle value at least 1.6-fold (0.22 log units) from the limit.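

In this assay, the weakening at this amine nitrogen is not confined to butyl: acetyl also gives an at least 9.5-fold higher number from compound 1 to compound 3 (0.97 log units; beyond the scatter). Of the three compounds, only compound 1, with hydrogen on this nitrogen, gives a readable number, and both substituted compounds lose it. Butyl and acetyl cannot be ranked, because the step between compound 2 and compound 3 is unreadable with both values at a limit of the assay: the limit of > 50000 nM in this assay, at which 2 of the 3 values shown sit.

On these data alone, whether methyl on this amine nitrogen retains any inhibition remains open. As far as these compounds go, how far compound 2 and compound 3 lie beyond the limit also remains open.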